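Silicon for isopropyl on a sulfonamide aryl ring

A few compounds are considered here, and "the series" means these few. Any claim that something is new, unique, unknown or untested is made for them only; others in the source may bear on it.

Compound 1 `CC(C(=O)N1CCC(F)(F)CC1)N1CCN(S(=O)(=O)c2ccc(C(C)(C)C)cc2)CC1`: in an ADME assay on HepG2 cells (Homo sapiens) for inhibition, with a stated time of 48 h (on this read-out higher numbers stand for an effect only at larger amounts of compound and lower numbers for an effect already at smaller amounts), compound 1 gives > 40000 nM, a limit of the assay.
Compound 2 `CC(C(=O)N1CCc2ncccc2C1)N1CCN(S(=O)(=O)c2ccc(C(C)(C)C)cc2)CC1`: in this assay compound 2 gives > 40000 nM, a limit of the assay.
Compound 3 `CC(C)c1ccc(S(=O)(=O)N2CCN(C(C)C(=O)N3CCCC3)CC2)cc1`: in this assay compound 3 gives > 40000 nM, a limit of the assay.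

Among the measured compounds shown here, compound 3 stands where every compound so far stands: at the limit of > 40000 nM in this assay, at which 3 of the 3 values shown sit, so no number for it is known, only that any effect lies beyond what the assay can report. For the measured compounds named here, the one change between two measured compounds, a step that the two limits leave unreadable from compound 1 to compound 2, cannot be read either, since both of its ends are limits.

Compound 4 `CC(C(=O)N1CCCC1)N1CCN(S(=O)(=O)c2ccc([Si](C)(C)C)cc2)CC1` differs from compound 3 by a group of 4 heavy atoms (3 carbon, 1 silicon; no ring) in place of a group of 3 heavy atoms (3 carbon; no ring), on an aromatic carbon. Going by the values given here, no measured step touches this part of the shared core, and no measured step gives a readable size at all. The expectation for compound 4 therefore rests on the three limits alone and is a step that the limit leaves unreadable from compound 3 to compound 4, that is, none beyond the scatter. Compound 4 is expected to give about 60000 nM in this assay, within a range of 20000 nM to 200000 nM, most likely reported again as a limit.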

Compound 4, half-maximal effective concentration: > 40000 nM
Compound 4 ended at the assay's limit; the forecaster's own chance of this, stated with the estimate: 85%; the middle value lies beyond the limit too.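

The step from compound 3 to compound 4 cannot be read, since both compounds give only a limit in this assay and no number: the limit of > 40000 nM in this assay, at which 4 of the 4 values shown sit.

The compounds shown leave open whether putting the silicon-bearing group in place of isopropyl changes the effect on these cells at all.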